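This account rests on a few compounds, and the source may have more. Where it says the series, first, only, none or still open, it means among the compounds named here.

Compound 1 `O=c1cc(-c2ccccc2)oc2cc(-c3ccsc3)cc(O)c12`: 6%
Compound 2 `O=c1cc(-c2ccccc2)oc2cc(-c3ccoc3)cc(O)c12`: 29%

Of the compounds shown here, two have so far been measured in an assay for inhibition of CDK8/Cyclin C (Homo sapiens), read by ADP-Glo, with a stated time of 60 min, tested at 200 nM, in the presence of a further agent that is not named here; a higher number here means more inhibition at the concentration tested (going by the name of the read-out), a lower number less inhibition. Compound 1 gives 6%, and compound 2 gives 29%. Among the measured compounds shown here, the single step between them, a number 23 percentage points higher from compound 1 to compound 2 (beyond the scatter), is the only guide to how a change at this place of the shared core affects the read-out. For the measured compounds named here, compound 2 therefore holds the higher of the two numbers, with compound 1 as its only neighbour, lower by a margin beyond the scatter.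

Compound 3 `Cc1noc(C)c1-c1cc(O)c2c(=O)cc(-c3ccccc3)oc2c1` has not yet been measured. It differs from compound 2 in one place: 3,5-dimethyl-1,2-oxazol-4-yl in place of furan-3-yl on an aromatic carbon. Going by the values given here, no measured step shows exactly this exchange. What the data do show is that swapping the group at this place once moved the number by a number 23 percentage points higher from compound 1 to compound 2 (beyond the scatter), so a step of similar size in this assay is plausible, but its direction cannot be read from the two measured compounds, and a step within the scatter is equally possible.

On that basis compound 3 is expected to give about 20% in this assay, with a range from 0% to 50%. The step this estimate implies is a number 9 percentage points lower from compound 2 to compound 3 (within the scatter), an expectation carrying wide uncertainty.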

Compound 3, a percentage reported as inhibition, at one concentration (the size of the read-out at that concentration, not a potency): 12%
Compound 3: middle estimate off by 8 percentage points, on the high side, within the range that was stated.
By their numbers in this assay, from the lowest: compounds 1 and 3 (each within the scatter of the next); then compound 2.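

In this assay, the result gives this position a third five-membered aromatic ring, and exchanging furan-3-yl for 3,5-dimethyl-1,2-oxazol-4-yl gives a number 17 percentage points lower from compound 2 to compound 3 (beyond the scatter). Set against the sulfur-containing ring, the same group gives a number 6 percentage points higher from compound 1 to compound 3 (within the scatter), so thiophen-3-yl and 3,5-dimethyl-1,2-oxazol-4-yl cannot be told apart in this measurement. Among the compounds shown here, the earlier pair showed only that one ring exchange could change the read-out, whereas these three compounds show furan-3-yl standing clearly apart from both other groups, with compound 2 the highest of the set.

No supporting measurement explains why furan-3-yl differs from the other two groups, and three ring groups are too few to connect the read-out with ring size, hetero atoms or methyl groups. Still open, on these data alone, is how the read-out would respond at this place to a group of another kind, such as an amine, a carboxylic acid or a longer chain, and whether any such group would exceed the value of compound 2 at 29%.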